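The source may hold more compounds than are shown below. What is called first, only, known or untested is meant among the compounds shown, and "the series" means these compounds.

Compound 3 `FC(F)(F)c1cccc(NC(=S)NCc2ccco2)c1` is the starting point here. Among the measured compounds shown here, in an ADME assay on MT4 cells (Homo sapiens) for cytotoxicity (on this read-out higher numbers stand for lower toxicity in this test and lower numbers for higher toxicity in this test), compound 3 gives 43000 nM, the highest of the three numbers measured so far. Compound 1 `COc1cccc(NC(=S)Nc2cccc(C(F)(F)F)c2)c1` gives 26000 nM in this assay, which sits within the scatter of compound 3, while compound 2 `FC(F)(F)c1cccc(NC(=S)Nc2ccc(I)cc2)c1` gives 10000 nM, the lowest of the three. For the measured compounds named here, the one step that joins two measured compounds in a single place runs a 4.3-fold higher number from compound 2 to compound 3 (0.63 log units; beyond the scatter), a change in which (furan-2-yl)methyl took the place of 4-iodophenyl on an amide-type nitrogen.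

Compound 4 `Fc1cccc(NC(=S)Nc2cccc(C(F)(F)F)c2)c1` has not yet been measured in this assay. It differs from compound 3 by 3-fluorophenyl in place of (furan-2-yl)methyl on an amide-type nitrogen. Going by the values given here, this change moves back in the direction of the aryl-substituted compounds 1 and 2, and the step from compound 2 to compound 3 is the one measured step that bears on it directly. Read in reverse, that step points toward a lower number for compound 4, though compound 1, which also carries a six-membered aromatic ring on that nitrogen, sits within the scatter of compound 3, so a modest shift at most is expected. Compound 4 is therefore estimated to give 20000 nM in this assay, within a range of 8000 nM to 45000 nM, an expected step of a 2.2-fold lower number from compound 3 to compound 4 (0.33 log units; beyond the scatter).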

Compound 4, half-maximal cytotoxic concentration: 20000 nM
The estimate for compound 4 equals the measured number at the digits printed, and the stated range covers the measured number.
By their numbers in this assay, from the lowest: compounds 2, 4, 1 and 3 (each within the scatter of the next, the first and the last beyond it).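

Compound 4 gives a second case of a six-membered aromatic ring replacing or being replaced by (furan-2-yl)methyl on the amide-type nitrogen: in this assay, the change shows a 2.2-fold lower number from compound 3 to compound 4 (0.33 log units; beyond the scatter), which runs the same way as the earlier step involving 4-iodophenyl. The aryl compounds themselves are not separated at this position, since a 2.0-fold higher number from compound 2 to compound 4 (0.30 log units; within the scatter) and a 1.3-fold lower number from compound 1 to compound 4 (0.11 log units; within the scatter) both stay within the scatter, so neither 3-fluorophenyl in place of 4-iodophenyl nor fluoro in place of methoxy on an aromatic carbon gives a readable change here. The link between an aryl group and a lower number is therefore only partial, and compound 1 goes against it, with 26000 nM lying within the scatter of compound 3.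

Nothing shown explains why (furan-2-yl)methyl and 3-fluorophenyl differ in this test. On these data alone, it remains open how an amine or a carboxylic acid on the aromatic ring would read here, and whether a longer chain carrying the five-membered aromatic ring would keep the higher number of compound 3.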